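Swapping bromo for methoxy on the imine-side aryl ring

This account rests on a few compounds, and the source may have more. Where it says the series, first, only, none or still open, it means among the compounds named here.

Among the compounds with values here, in a functional assay on WM 266-4 cells (Homo sapiens) for inhibition, read by MTT assay, with a stated time of 24 h (on this read-out lower numbers stand for stronger inhibition of growth and higher numbers for weaker inhibition of growth), compound 3 `COc1ccc(C2CC(c3ccc(Br)cc3)=NN2C(=O)C2COc3ccccc3O2)cc1` gives 9010 nM, the highest of the three numbers so far. Compound 2 `O=C(C1COc2ccccc2O1)N1N=C(c2ccc(Br)cc2)CC1c1ccccc1F` gives 8030 nM, and the step of a 1.1-fold higher number from compound 2 to compound 3 (0.05 log units; within the scatter) shows that this change hardly matters. Compound 1 `COc1ccc(C2=NN(C(=O)c3ccc4c(c3)OCCO4)C(c3ccc(F)cc3)C2)cc1` gives 3780 nM, a lower number, but it differs from compound 3 in more than one place. Compound 4 `COc1ccc(C2=NN(C(=O)C3COc4ccccc4O3)C(c3ccc(OC)cc3)C2)cc1` carries methoxy in place of bromo on an aromatic carbon. Within the data shown here, no measured step covers this change directly, so the expectation rests loosely on compound 1 and its value of 3780 nM, which also has a methoxyphenyl on that carbon. The expected step of a 1.4-fold lower number from compound 3 to compound 4 (0.14 log units; within the scatter) is therefore small. Compound 4 is estimated at 6500 nM, within 2500 nM to 16000 nM.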

Compound 4, concentration for 50% growth inhibition: 11000 nM
Compound 4: the middle estimate sits 1.7-fold (0.23 log units) below what was measured; low and high end bracket the measured number.
By their numbers in this assay, from the lowest: compound 1; then compounds 2, 3 and 4 (each within the scatter of the next).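

In this assay, the 4-bromophenyl to 4-methoxyphenyl change gives a 1.2-fold higher number from compound 3 to compound 4 (0.09 log units; within the scatter), so this aromatic position shows no readable difference between bromo and methoxy. Exchanging one heavy atom for two and adding a hydrogen-bond acceptor there leaves growth inhibition in the same range. Nothing available here explains why the two groups read alike.

Going by these compounds, whether an amine or a carboxylic acid on this aromatic carbon would shift the number remains open. Also open, on these data alone, is which structural difference sets compound 1 apart, since it differs from compound 4 in more than one place.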